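The source may report more compounds than this note shows. Statements on the series, on what has been measured and on what is new or still open speak of the compounds shown alone.

Measured in a functional assay on HOS-TE85 cells (Homo sapiens) for inhibition, read by CCK-8 assay, with a stated time of 72 h; on this read-out higher numbers stand for weaker inhibition and lower numbers for stronger inhibition:

Compound 1 `O=C(NCCCCc1ccccc1)c1cccc(C2SCC(=O)N2c2ccc(-c3ccccc3)cc2)c1`: > 1000 nM
Compound 2 `O=C(NCCCc1ccccc1)c1cccc(C2SCC(=O)N2c2ccc(C3CC3)cc2)c1`: > 1000 nM

Compound 2 gives > 1000 nM, which is a limit of this assay and not a number. Compound 1 gives > 1000 nM, also a limit. The record so far is therefore (the limit of > 1000 nM in this assay, at which 2 of the 2 values shown sit).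

Compound 3 `O=C(NCCCCc1ccccc1)c1cccc(C2SCC(=O)N2c2ccc(C3CC3)cc2)c1` differs from compound 2 by one change, benzyl in place of phenyl on a saturated chain carbon, three bonds along the chain from an amide-type nitrogen. The same difference reads as 3-phenylpropyl to 4-phenylbutyl. Among the compounds with values here, no measured step shows the size of this change, so a shift beyond the usual scatter is not expected in either direction. The expected step is a step that the limit leaves unreadable from compound 2 to compound 3. For compound 3 the estimated value is 1500 nM, with an expected range of 400 nM to 5000 nM.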

Compound 3, half-maximal inhibitory concentration: 217 nM
Beside the measured number, compound 3's estimate is 6.9-fold (0.84 log units) above it, outside the stated range (below it).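

In this assay, the saturated chain now shows that it matters: with cyclopropyl held fixed, going from 3-phenylpropyl to 4-phenylbutyl gives an at least 4.6-fold lower number from compound 2 to compound 3 (0.66 log units; beyond the scatter). The aromatic carbon matters as well, since with the 4-phenylbutyl chain held fixed, cyclopropyl in place of phenyl gives an at least 4.6-fold lower number from compound 1 to compound 3 (0.66 log units; beyond the scatter). The true size of both steps remains unknown, and each gives only a minimum because its starting compound rests on a limit of the assay: the limit of > 1000 nM in this assay, at which 2 of the 3 values shown sit.

The compounds shown leave open whether a longer chain, such as 5-phenylpentyl, would lower the number further or lose the gain. They also leave open whether a smaller group on the same aromatic carbon, such as methyl or a chlorine atom, could stand in for cyclopropyl.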